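A phenyl for a methyl on the ring nitrogen, tried twice

The source may report more compounds than this note shows. Statements on the series, on what has been measured and on what is new or still open speak of the compounds shown alone.

Measured in a functional assay on the whole organism (strain Swiss albino) with Mus musculus as the target, in the maximal electroshock model, with a stated time of 2 h; on this read-out lower numbers stand for an effect already at smaller amounts and higher numbers for an effect only at larger amounts of compound:
compound 1 `CN1C(=O)C(c2ccccc2)CC(c2ccccc2)C1=O`: 14.8 mg/kg
compound 2 `O=C1C(c2ccccc2)CC(c2ccccc2)C(=O)N1c1ccccc1`: 43.7 mg/kg
compound 3 `CN1C(=O)C(c2ccccc2Cl)CC(c2ccccc2Cl)C1=O`: 23.7 mg/kg

One change is known from measured compounds: phenyl in place of methyl on an amide-type nitrogen in a ring. This gave a 3.0-fold higher number from compound 1 to compound 2 (0.47 log units; beyond the scatter). Compound 3 and compound 1 lie within the scatter of each other in this assay; how their cores differ is not broken down here.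

Compound 4 `O=C1C(c2ccccc2Cl)CC(c2ccccc2Cl)C(=O)N1c1ccccc1` is not yet measured. It arises from compound 3 by phenyl in place of methyl on an amide-type nitrogen in a ring. This is the same kind of change as from compound 1 to compound 2, not the same one: there the two ring atoms each bear a phenyl group, here each bears a 2-chlorophenyl group.

Going by the values given here, for compound 4 a step of a 3.0-fold higher number from compound 3 to compound 4 (0.47 log units; beyond the scatter) is expected, close to the earlier one, because the only guide is a 3.0-fold higher number from compound 1 to compound 2 (0.47 log units; beyond the scatter). Compound 4 is therefore estimated at 70 mg/kg, expected between 35 mg/kg and 140 mg/kg.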

Compound 4, dose for half-maximal effect: 61.4 mg/kg
For compound 4 the middle estimate is 1.1-fold (0.06 log units) above the measured one, and the stated range covers the measured number.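

In this assay, putting phenyl in place of methyl on the ring nitrogen again gives a higher number, here a 2.6-fold higher number from compound 3 to compound 4 (0.41 log units; beyond the scatter). The change carries over from the core bearing phenyl groups to the core bearing 2-chlorophenyl groups, with steps of similar size: the same change on two cores in this assay, a 3.0-fold higher number (0.47 log units; beyond the scatter) from compound 1 to compound 2 and a 2.6-fold higher number (0.41 log units; beyond the scatter) from compound 3 to compound 4, 1.1-fold (0.06 log units) apart, within the scatter of two such steps. This holds for these two cores only, and it shows neither why the number rises nor how the change would behave on a different core.

Still open, from the compounds shown here alone, is what other groups on the ring nitrogen would give, such as a benzyl group or a longer chain. Also open, going by these compounds, is whether the step would keep its size with a methoxy group on the outer rings in place of chlorine.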